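The source may hold more compounds than are shown below. What is called first, only, known or untested is meant among the compounds shown, and "the series" means these compounds.

Compound 1 `CCO/C(O)=C1\C(COCCNC(C)=O)=NC(C)=C(C(=O)OC)C1c1ccccc1Cl` is one of three close relatives measured in a functional assay (aorta) with Rattus norvegicus as the target; a lower number here means a stronger inhibitor, a higher number a weaker inhibitor. In this assay compound 1 gives 15.9 nM. Compound 2 `CCO/C(O)=C1\C(COCCNC(=O)c2cccnc2)=NC(C)=C(C(=O)OC)C1c1ccccc1Cl` gives 15.9 nM, and the step of no change at the digits printed from compound 1 to compound 2 (within the scatter) shows nothing beyond the scatter. Compound 3 `CCO/C(O)=C1\C(COCCNCC(=O)NCCOC)=NC(C)=C(C(=O)OC)C1c1ccccc1Cl` gives 5.01 nM. Compound 1 thus stands level with compound 2, the pair together giving the highest of the three numbers, while compound 3 is furthest from compound 1, the step being a 3.2-fold lower number from compound 1 to compound 3 (0.50 log units; beyond the scatter).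

Compound 4 `CCO/C(O)=C1\C(COCCNCC(=O)NCCN)=NC(C)=C(C(=O)OC)C1c1ccccc1Cl` has not yet been measured. It differs from compound 1 in one place: ((2-aminoethyl)carbamoyl)methyl in place of acetyl on an amine nitrogen. Within the data shown here, the nearest measured guide is the step of a 3.2-fold lower number from compound 1 to compound 3 (0.50 log units; beyond the scatter), where acetyl on the same amine nitrogen was likewise replaced by a carbamoylmethyl chain, there ((2-methoxyethyl)carbamoyl)methyl rather than ((2-aminoethyl)carbamoyl)methyl; no measured pair separates those two chains. A step of similar modest size and the same direction is therefore expected, a 2.5-fold lower number from compound 1 to compound 4 (0.40 log units; beyond the scatter). Compound 4 is estimated to give 6.3 nM, with a range from 2.5 nM to 16 nM.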

Compound 4, half-maximal inhibitory concentration: 100 nM
Compound 4: the middle estimate sits 16-fold (1.20 log units) below what was measured; measured number outside the range, above it.
By their numbers in this assay, from the lowest: compound 3; then compounds 1 and 2 (each within the scatter of the next); then compound 4.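

In this assay, the end of the chain on this amine nitrogen decides the result: with amino in place of methoxy and nothing else altered, the outcome is (a 20-fold higher number from compound 3 to compound 4 (1.30 log units; beyond the scatter)), so the carbamoylmethyl chain alone does not bring the lower number seen for compound 3. The acetyl and (pyridin-3-yl)carbonyl compounds gave the same value at the digits printed, yet the new chain also falls behind both, with (a 6.3-fold higher number from compound 1 to compound 4 (0.80 log units; beyond the scatter)) and (a 6.3-fold higher number from compound 2 to compound 4 (0.80 log units; beyond the scatter)). No measurement shown here explains the effect of the amino group.

On these data alone, it remains open whether a hydroxyl or a dimethylamino group at the chain end would track methoxy or amino. Also open, as far as these compounds go, is whether a longer chain carrying the same terminal amine, or an acetyl placed on that amine, would change the number.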